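This account rests on a few compounds, and the source may have more. Where it says the series, first, only, none or still open, it means among the compounds named here.

Measured so far in a functional assay on CCRF-CEM cells for antagonist activity at C-X-C chemokine receptor type 4 (Homo sapiens), read by calcium flux, with stated times of 25 min and 90 s; a higher number here means a weaker inhibitor, a lower number a stronger inhibitor:
- compound 1, `CN(C[C@H]1Cc2c(cccc2N2C[C@@H]3C[C@H]2CN3)CN1)[C@H]1CCCc2cccnc21`: 146 nM
- compound 2, `CN(C[C@H]1Cc2c(cccc2N2CCNCC2)CN1)[C@H]1CCCc2cccnc21`: 6.08 nM
- compound 3, `FC1(F)CCC(CN(C[C@H]2Cc3c(cccc3N3CCNCC3)CN2)[C@H]2CCCc3cccnc32)CC1`: 498 nM

Compound 2 gives the lowest number of the three in this assay. Its nearest neighbour on the numbers is compound 1, with a 24-fold lower number from compound 1 to compound 2 (1.38 log units; beyond the scatter); its furthest is compound 3, with an 82-fold higher number from compound 2 to compound 3 (1.91 log units; beyond the scatter). Both steps are beyond the scatter, so compound 2 is the strongest inhibitor among the measured set.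

Compound 4, `C[C@@H]1CN(c2cccc3c2C[C@H](CN(C)[C@H]2CCCc4cccnc42)NC3)C[C@H](C)N1C`, differs from compound 2 only at the aromatic carbon: 3,4,5-trimethylpiperazin-1-yl in place of piperazin-1-yl on an aromatic carbon. Going by the values given here, of the measured steps, only the one from compound 1 to compound 2 touches the same place, and it shows that the ring on that aromatic carbon can move the number by a large amount. The step from compound 2 to compound 3 lies at a saturated chain carbon bound to an amine nitrogen and does not bear on this change. Among the compounds with values here, no measured pair shows methyls added to the piperazin-1-yl or the loss of its hydrogen-bond donor, so the direction rests on the single relevant step, which favours the unsubstituted ring. A moderate rise beyond the scatter is therefore expected, a 4.9-fold higher number from compound 2 to compound 4 (0.69 log units; beyond the scatter).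

Compound 4 is estimated at 30 nM in this assay, with a range of 8 nM to 150 nM.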

Compound 4, half-maximal inhibitory concentration: 14.1 nM
For compound 4 the middle estimate is 2.1-fold (0.33 log units) above the measured one, and the stated range covers the measured number.
By their numbers in this assay, from the lowest: compound 2; then compound 4; then compound 1; then compound 3.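

In this assay, the aromatic carbon accepts 3,4,5-trimethylpiperazin-1-yl at only a modest cost, a 2.3-fold higher number from compound 2 to compound 4 (0.37 log units; beyond the scatter), even though the entering group has 0 hydrogen-bond donors and 2 defined stereocentres; the hydrogen-bond donor of piperazin-1-yl is therefore not required for a number in this range. The substituted ring also stays well ahead of the group on compound 1, a 10-fold lower number from compound 1 to compound 4 (1.02 log units; beyond the scatter), so heavy-atom count alone does not order these three compounds: the group on compound 4 is the largest, that on compound 2 the smallest, and the intermediate group on compound 1 gives the highest number of the three. Nothing on hand explains either step.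

Going by these compounds alone, the single change adds the ring methyls and the nitrogen methyl together, so the share of each remains open, and 4-methylpiperazin-1-yl and 3,5-dimethylpiperazin-1-yl would separate them. Also open, going by these compounds, is how a morpholine or an open-chain amine on this aromatic carbon would compare, and whether the ranking of these rings holds with 4,4-difluorocyclohexyl on the chain.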